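A few compounds are considered here, and "the series" means these few. Any claim that something is new, unique, unknown or untested is made for them only; others in the source may bear on it.

Working notes on the series. Compound 1 `COc1ccc(OC)c(Sc2ccc3nnc(-c4ccccn4)n3n2)c1` and compound 2 `COc1ccc(OC)c(Sc2ccc3nnc(-c4cccnc4)n3n2)c1` share one core and differ only in the pyridyl isomer. In an assay on HEK293 cells for inhibition of Leucine-rich repeat serine/threonine-protein kinase 2 (Homo sapiens), read by ELISA, with a stated time of 90 min (on this read-out higher numbers stand for weaker inhibition and lower numbers for stronger inhibition), compound 1 gives 1310 nM and compound 2 gives 736 nM. Among the measured compounds shown here, the only recorded step, a 1.8-fold lower number from compound 1 to compound 2 (0.25 log units; within the scatter), lies within the scatter. In this assay compound 3 `COc1ccc(OC)c(Sc2ccc3nnc(-c4cnccn4)n3n2)c1` gives "not determined" (no result reported), so no result is reported for it. Of the two numbers, compound 2 stands at the low end, with compound 1 within the scatter of it. Compound 4 `COc1cncc(-c2nnc3ccc(Sc4cc(OC)ccc4OC)nn23)c1` differs from compound 2 by methoxy in place of hydrogen on an aromatic carbon. For the measured compounds named here, no measured step bears on this change, since the one step recorded concerns the pyridyl isomer and not a methoxy. In this assay the step of a 1.1-fold lower number from compound 2 to compound 4 (0.02 log units; within the scatter) is therefore expected to stay within the scatter. Compound 4 is estimated at 700 nM, with a range of 250 nM to 2000 nM.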

Compound 4, half-maximal inhibitory concentration: 440 nM
Estimate against measurement, compound 4: 1.6-fold (0.20 log units) above; low and high end bracket the measured number.
By their numbers in this assay, from the lowest: compounds 4, 2 and 1 (each within the scatter of the next, the first and the last beyond it).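

In this assay the step of methoxy in place of hydrogen on the pyridin-3-yl group, two atoms from the ring nitrogen, is a 1.7-fold lower number from compound 2 to compound 4 (0.22 log units; within the scatter) and so shows that this position accepts methoxy with no change beyond the scatter. Among the compounds shown here, the wider change to 5-methoxypyridin-3-yl from pyridin-2-yl is a 3.0-fold lower number from compound 1 to compound 4 (0.47 log units; beyond the scatter) and is the first step to pass the scatter, though only modestly. Nothing measured here bears on a cause. Left open is how an amine, a carboxylic acid or a longer ether chain at this position would read out.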